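Swapping fluorines for methyls on the sulfonyl-bound ring

The source may report more compounds than this note shows. Statements on the series, on what has been measured and on what is new or still open speak of the compounds shown alone.

Compound 1 `COc1ccc(-c2c(S(=O)(=O)c3ccc(F)c(F)c3)cnc3cc(F)ccc23)cc1` was tested in an ADME assay on microsomes from liver (Homo sapiens) for metabolic stability, tested at 2.5 uM (on this read-out lower numbers stand for slow clearance and higher numbers for fast clearance), where compound 1 gives 1.1 mL/min. Among the compounds with values here, this is the higher of the two numbers recorded; the only other measured compound, compound 2 `O=S(=O)(c1ccc(F)c(F)c1)c1cnc2cc(F)ccc2c1-c1ccccc1F`, gives 0.79 mL/min in this assay, and the change a 1.4-fold lower number from compound 1 to compound 2 (0.14 log units; within the scatter) lies within the scatter of the method. Compound 3 `COc1ccc(-c2c(S(=O)(=O)c3ccc(C)c(C)c3)cnc3cc(F)ccc23)cc1` has not yet been measured in this assay. Compound 3 differs from compound 1 in one place: 3,4-dimethylphenyl in place of 3,4-difluorophenyl on a sulfonyl sulfur. Within the data shown here, no measured step touches the group on the sulfonyl sulfur; the single step recorded concerns a different position of the shared core and was itself within the scatter, so it offers no guidance on direction. The expectation for compound 3 therefore rests on the value of compound 1 alone, and the step of a 1.4-fold higher number from compound 1 to compound 3 (0.13 log units; within the scatter) is expected to stay close to the scatter. On this basis compound 3 is estimated to give 1.5 mL/min in this assay, within a range from 0.7 mL/min to 3.2 mL/min.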

Compound 3, intrinsic clearance in a liver preparation (reported as CLH), per the amount of preparation that the assay uses: 4.13 mL/min
Compound 3: middle estimate off by 2.8-fold (0.44 log units), on the low side; the measured number lies above the stated range.
By their numbers in this assay, from the lowest: compounds 2 and 1 (each within the scatter of the next); then compound 3.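

Within the data shown here, the group on the sulfonyl sulfur proves to matter in this assay: 3,4-dimethylphenyl in place of 3,4-difluorophenyl gives a clear rise (a 3.8-fold higher number from compound 1 to compound 3 (0.57 log units; beyond the scatter)), whereas the only earlier step concerned a different position of the shared core and stayed within the scatter. The exchange keeps the number of heavy atoms and the carbon-only aromatic ring, and it replaces the two fluorines with two carbons, so a change this limited at this position is enough to move the read-out towards faster clearance. Nothing shown accounts for the rise.

On these data alone, it remains open whether both methyl groups are needed for this rise or one would produce it alone. Also open, as far as these compounds go, is how a chlorine or a nitrile on this ring would compare with compound 1.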